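Replacing the nitrile of compound 1 with a methyl ester

The compounds below may be only part of what the source reports. "The series", "measured", "known", "first", "only" and "open" are said of these compounds alone.

Compound 1, `COC(=O)N(C)COc1ccc(C#N)cc1`, in an ADME assay for pharmacokinetics (a lower number here means that the compound disappears faster, a higher number that the compound lasts longer), gives 2.48 h.
Compound 2, `COC(=O)N(C)COc1ccc(C=O)cc1`, in this assay gives 1.25 h.
Compound 3, `COC(=O)N(C)COc1ccccc1C=O`, in this assay gives 0.2 h.

Compound 1 shows the longest of the three half-lives, but compound 2 comes close: the step of a 2.0-fold lower number from compound 1 to compound 2 (0.30 log units; within the scatter). Compound 3 lies far beneath compound 1, beyond the scatter. Compound 4, `COC(=O)c1ccc(OCN(C)C(=O)OC)cc1`, differs from compound 1 by methoxycarbonyl in place of cyano on an aromatic carbon. For the measured compounds named here, the only measured step that bears on this is the one a 2.0-fold lower number from compound 1 to compound 2 (0.30 log units; within the scatter), which also exchanged the cyano of compound 1 for a carbonyl-bearing group at the same place and stayed within the scatter. A step of similar size, or none beyond the scatter, is therefore expected in this assay, slightly shortening the half-life. Compound 4 is estimated at 1.8 h, range 0.8 h to 4 h, an expected step of a 1.4-fold lower number from compound 1 to compound 4 (0.14 log units; within the scatter).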

Compound 4, half-life: 4.83 h
The estimate for compound 4 lay 2.7-fold (0.43 log units) below the measured number; the measured number lies above the stated range.
By their numbers in this assay, from the lowest: compound 3; then compounds 2, 1 and 4 (each within the scatter of the next, the first and the last beyond it).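

On this aromatic carbon, methoxycarbonyl can stand in place of cyano with no shift beyond the scatter in this assay: a 1.9-fold higher number from compound 1 to compound 4 (0.29 log units; within the scatter). Methoxy in place of hydrogen on the carbonyl carbon gives the first single change here that goes beyond the scatter, a 3.9-fold higher number from compound 2 to compound 4 (0.59 log units; beyond the scatter), so what sits on that carbonyl carbon matters at this place. Nothing available accounts for this step.

On these data alone, how a carboxylic acid or an ethyl ester would behave at this place remains open. So does whether the methoxy-for-hydrogen step carries over to the core of compound 3.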